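The source may hold more compounds than are shown below. What is called first, only, known or untested is meant among the compounds shown, and "the series" means these compounds.

In a physicochemical assay for solubility, read by chemiluminescence, in phosphate buffer, measured as kinetic solubility, at pH 7.4 (a lower number here means a less soluble compound, a higher number a more soluble compound), three compounds have been measured so far. Compound 1 `Cc1cnc(Nc2ccc(C(=O)NCC3(c4nc(-c5ccccc5)cs4)CCOCC3)cc2)s1` gives < 1000 nM, which is a limit of the assay and not a number. Compound 2 `Cc1cc(C)n(Cc2ccc(C(=O)NCC3(c4ccccn4)CCOCC3)cc2)n1` gives >= 445000 nM, which is also only a limit of the assay. Compound 3 `COc1ccccc1-c1csc(C2(CNC(=O)c3ccc(Cn4nc(C)cc4C)cc3)CCOCC2)n1` gives a measured number, 78000 nM. These three compounds differ in more than one place, so no single change can be read directly from them.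

Compound 4 `O=C(NCC1(c2nc(-c3ccccc3)cs2)CCOCC1)c1ccc(-n2ccnc2)cc1` has not yet been measured. It keeps the core of compound 1 and changes one group: 1H-imidazol-1-yl in place of (5-methyl-1,3-thiazol-2-yl)amino on an aromatic carbon. The 1H-imidazol-1-yl group takes the place of (5-methyl-1,3-thiazol-2-yl)amino on an aromatic carbon of the six-membered aromatic ring of carbon only, para to a large group. A rise in this assay is expected, well beyond the usual scatter. This expectation rests on compound 3, which lacks the (5-methyl-1,3-thiazol-2-yl)amino group and gives 78000 nM. The expected step is an at least 30-fold higher number from compound 1 to compound 4 (1.47 log units; beyond the scatter), and it remains rough since it starts from a limit. For compound 4 the estimate is 30000 nM, with an expected range from 5000 nM to 150000 nM.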

Compound 4, solubility: 193000 nM
Estimate against measurement, compound 4: 6.4-fold (0.81 log units) below, outside the stated range (above it).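

On the six-membered aromatic ring of carbon only, para to a large group, putting 1H-imidazol-1-yl in place of (5-methyl-1,3-thiazol-2-yl)amino gives an at least 190-fold higher number from compound 1 to compound 4 (2.28 log units; beyond the scatter) in this assay, the only change among the compounds shown that can be read in one place, and it shows that the core of compound 1 can carry a high reading once this one group is exchanged. Compound 1 gives < 1000 nM, which is a limit of the assay and not a number. The size of the step is therefore only a lower bound, because one end of it stands at a limit: the limit of < 1000 nM in this assay, at which 1 of the 4 values shown sits.

Which part of the exchange carries the step stays open, as the two groups differ at once in their ring, in the amino link and in their counts of hydrogen-bond donors and acceptors. A simple amine or a carboxylic acid at this same place on the same core would show whether the high reading is tied to a five-membered aromatic ring with 2 hetero atoms or also holds without one.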